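Cyano to chloro on the shared core of compound 1

A few compounds are considered here, and "the series" means these few. Any claim that something is new, unique, unknown or untested is made for them only; others in the source may bear on it.

Measured so far:
compound 1 `CCc1nnc2c(C#N)c(N3CCC(c4ccccc4)CC3)ccn12`: 696 nM
compound 2 `CC(C)(C)c1nnc2c(C#N)c(N3CCC(c4ccccc4)CC3)ccn12`: 1230 nM

Compound 1 gives the lowest of the two numbers in a functional assay on CHO cells for positive allosteric modulation of metabotropic glutamate receptor 2 (Homo sapiens), read by GTPgammaS binding, with a stated time of 30 min; a higher number here means that more compound is needed for the effect, a lower number that less compound is needed; its nearest neighbour is compound 2, and the step of a 1.8-fold higher number from compound 1 to compound 2 (0.25 log units; within the scatter) is within the scatter, so the two compounds cannot be ordered on these data.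

Compound 3 `CCc1nnc2c(Cl)c(N3CCC(c4ccccc4)CC3)ccn12` has not been measured. It differs from compound 1 in one place: chloro in place of cyano on an aromatic carbon.

Going by the values given here, no measured step bears on this change. Among the compounds with values here, the only step on record, a 1.8-fold higher number from compound 1 to compound 2 (0.25 log units; within the scatter), concerns the group on the other aromatic carbon, where tert-butyl in place of ethyl stayed within the scatter; it says nothing about the cyano position. The change in compound 3 is therefore untested in this series, and the expectation rests on the structural change alone.

Compound 3 is expected to land close to compound 1, with a step of a 1.4-fold higher number from compound 1 to compound 3 (0.16 log units; within the scatter) that may not exceed the scatter. The estimated value for compound 3 is 1000 nM, in the range 300 nM to 3500 nM.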

Compound 3, half-maximal effective concentration: 386 nM
For compound 3 the middle estimate is 2.6-fold (0.41 log units) above the measured one; low and high end bracket the measured number.
By their numbers in this assay, from the lowest: compounds 3, 1 and 2 (each within the scatter of the next, the first and the last beyond it).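

In this assay, the aromatic carbon that carries the cyano group in compound 1 now has its first reading: chloro in place of cyano gives a 1.8-fold lower number from compound 1 to compound 3 (0.26 log units; within the scatter), so compound 1 and compound 3 cannot be ordered on these data. On the core of compound 1, the nitrile, with 2 heavy atoms and 1 hydrogen-bond acceptor, is therefore not needed for a number in this range, as chloro, with 1 heavy atom and 0 hydrogen-bond acceptors, stands within the scatter of it. No measurement at hand accounts for this result or ties it to any feature of either group.

Open is whether chloro would read the same with tert-butyl in place of ethyl, as the one chloro compound shown carries ethyl. Also open, on these data alone, is how far this position reaches beyond these two groups: bromo, methyl, methoxy or a plain hydrogen there would show whether the numbers stay within the scatter of compound 1 or move clearly away from it.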